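A few compounds are considered here, and "the series" means these few. Any claim that something is new, unique, unknown or untested is made for them only; others in the source may bear on it.

Measured so far:
Compound 1 `CC(O)(C(=O)Nc1ccc(C#N)c(Sc2ccccc2)c1)C(F)(F)F`: 8300 nM
Compound 2 `CC(O)(C(=O)Nc1ccc(S(=O)(=O)c2ccccc2C#N)cc1)C(F)(F)F`: 1100 nM

Both compounds share a core carrying a hydroxy, a methyl and a trifluoromethyl on the carbon beside the amide carbonyl, and differ in how the second aromatic ring is attached. In a functional assay (Cavia porcellus) with sulfonylurea receptors; K-ATP channels (Homo sapiens) as the target (on this read-out higher numbers stand for weaker inhibition and lower numbers for stronger inhibition), compound 2 gives 1100 nM, the lower of the two numbers; compound 1 gives 8300 nM, a gap that lies beyond the usual scatter. For the measured compounds named here, no single-change step between measured compounds is available, so the effect of the next change cannot be read off directly.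

Compound 3 `Cc1cccc(S(=O)(=O)c2ccc(NC(=O)C(C)(O)C(F)(F)F)cc2)c1` is not yet measured. Its difference from compound 2 is 3-methylphenyl in place of 2-cyanophenyl on a sulfonyl sulfur. The nitrile that leaves takes the only hydrogen-bond acceptor of that ring with it. Without a measured reference for this exchange, a weakening of modest size, roughly at the edge of the scatter, is expected, a 2.3-fold higher number from compound 2 to compound 3 (0.36 log units; beyond the scatter). Compound 3 is estimated at 2500 nM, within a range of 600 nM to 10000 nM.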

Compound 3, half-maximal inhibitory concentration: 2200 nM
Estimate against measurement, compound 3: 1.1-fold (0.06 log units) above, and the stated range covers the measured number.
By their numbers in this assay, from the lowest: compounds 2 and 3 (each within the scatter of the next); then compound 1.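

In this assay, putting 3-methylphenyl in place of 2-cyanophenyl on a sulfonyl sulfur gives a 2.0-fold higher number from compound 2 to compound 3 (0.30 log units; within the scatter), so the two compounds cannot be told apart on this read-out. This shows that this position tolerates losing the nitrile and its hydrogen-bond acceptor without a readable change in the number, something the earlier pair, which differs in more than one place, could not show. Nothing measured here explains this result.

The group and its place on the ring change together in this step, so 3-cyanophenyl or 2-methylphenyl would be needed to tell those two changes apart. Going by these compounds, whether an amine or a carboxylic acid on this ring would move the number beyond the scatter also stays open.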